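The compounds below may be only part of what the source reports. "The series", "measured", "known", "first", "only" and "open" are said of these compounds alone.

Three ureas on a shared core have been measured in a functional assay on cells (Neutrophil, Homo sapiens) for inhibition, with a stated time of 10 min; a higher number here means a weaker inhibitor, a lower number a stronger inhibitor. Compound 1 `CCOC(=O)c1cnn(CC(O)CC)c1NC(=O)NC(C)C` gives 0.0042 nM, compound 2 `CCCC(O)Cn1ncc(C(=O)OCC)c1NC(=O)NCc1ccccc1` gives 0.0032 nM, and compound 3 `CCOC(=O)c1cnn(CC(O)CC)c1NC(=O)NCc1ccccc1` gives 0.0074 nM. Compound 2 has the lowest of the three numbers; its nearest neighbour is compound 1, within the scatter, and its furthest is compound 3, which lies a 2.3-fold higher number from compound 2 to compound 3 (0.36 log units; beyond the scatter), a modest step.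

The unmeasured compound 4 `CCCC(O)Cn1ncc(C(=O)OCC)c1NC(=O)NC(C)C` differs from compound 2 in one place: isopropyl in place of benzyl on an amide-type nitrogen. Among the measured compounds shown here, the one measured step that bears on this change is the reverse one, from compound 1 to compound 3, where benzyl replaced isopropyl and the number rose only a 1.8-fold higher number from compound 1 to compound 3 (0.25 log units; within the scatter), which is within the scatter. Running that change backwards from compound 2 therefore is expected to move the number little, if anything slightly lower, and the expected step is a 1.5-fold lower number from compound 2 to compound 4 (0.16 log units; within the scatter). On that basis compound 4 is estimated at 0.0022 nM, with a range from 0.001 nM to 0.005 nM.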

Compound 4, half-maximal inhibitory concentration: 1 nM
Estimate against measurement, compound 4: 450-fold (2.66 log units) below, outside the stated range (above it).
By their numbers in this assay, from the lowest: compounds 2, 1 and 3 (each within the scatter of the next, the first and the last beyond it); then compound 4.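

In this assay, two single changes each lead to the same outlying compound: isopropyl in place of benzyl on an amide-type nitrogen gives a 310-fold higher number from compound 2 to compound 4 (2.49 log units; beyond the scatter), and methyl in place of hydrogen on a saturated chain carbon, three bonds along the chain from an oxygen on a saturated carbon, gives a 240-fold higher number from compound 1 to compound 4 (2.38 log units; beyond the scatter). The step between benzyl and isopropyl therefore depends strongly on the chain it is paired with: the same change on two cores in this assay, a 1.8-fold higher number (0.25 log units; within the scatter) from compound 1 to compound 3 and a 310-fold lower number (2.49 log units; beyond the scatter) from compound 4 to compound 2, 550-fold (2.74 log units) apart, beyond the scatter of two such steps. The methyl step depends just as strongly on the group on the nitrogen, so the large loss appears only where isopropyl and the extra methyl occur together: the same change on two cores in this assay, a 2.3-fold higher number (0.36 log units; beyond the scatter) from compound 2 to compound 3 and a 240-fold lower number (2.38 log units; beyond the scatter) from compound 4 to compound 1, 550-fold (2.74 log units) apart, beyond the scatter of two such steps.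

On these data alone, what stays open is whether a cyclohexylmethyl or a phenethyl on that nitrogen would behave like benzyl or like isopropyl with this chain. As far as these compounds go, it is also open whether an ethyl on the same chain carbon would extend the pattern.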